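Working notes: 4-chlorobenzyl on the aromatic nitrogen of compound 2

The compounds below may be only part of what the source reports. "The series", "measured", "known", "first", "only" and "open" are said of these compounds alone.

Measured so far in a functional assay on HEK293 cells (Homo sapiens) for inhibition, read by MTT assay, with a stated time of 48 h; on this read-out lower numbers stand for stronger inhibition and higher numbers for weaker inhibition:
compound 1 `COc1cc(C2=NOC(c3c[nH]c4ccccc34)C2)cc(OC)c1OC`: 5000 nM
compound 2 `Cc1[nH]c2ccccc2c1C1CC(c2ccncc2)=NO1`: > 100000 nM
compound 3 `c1ccc2c(C3CC(c4ccncc4)=NO3)c[nH]c2c1`: > 100000 nM

Compound 2 stands at a limit of this assay, not at a number. Compound 3 likewise gives only a limit. Within the data shown here, the one measured step, a step that the two limits leave unreadable from compound 2 to compound 3, is therefore not readable, and the limit of > 100000 nM in this assay, at which 2 of the 3 values shown sit, is the reason both ends of it stay open. Among the measured compounds shown here, compound 1 is the only member with a number; its pair with compound 2 differs in the aryl group and no single step is given for it, so the two values show only that compound 1 is measurable where compound 2 is not.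

Compound 4 `Cc1c(C2CC(c3ccncc3)=NO2)c2ccccc2n1Cc1ccc(Cl)cc1` carries 4-chlorobenzyl in place of hydrogen on an aromatic nitrogen. For the measured compounds named here, no measured step touches the aromatic nitrogen, and the only step at hand, from compound 2 to compound 3, is unreadable, so nothing measured bears on this change.

The expected step of an at least 2.0-fold lower number from compound 2 to compound 4 (0.30 log units; that floor lies within the scatter) is therefore set with wide uncertainty and with a fair chance of another limit. Compound 4 is estimated at 50000 nM, in the range 8000 nM to 200000 nM.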

Compound 4, half-maximal inhibitory concentration: 2500 nM
Estimate against measurement, compound 4: 20-fold (1.30 log units) above; the measured number lies below the stated range.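

The aromatic nitrogen of compound 2 is a position that responds in this assay: 4-chlorobenzyl in place of hydrogen gives an at least 40-fold lower number from compound 2 to compound 4 (1.60 log units; beyond the scatter). Of compound 2, compound 3 and compound 4, which share a core apart from the changes shown, only compound 4 gives a number rather than a limit, so substitution on this nitrogen brings the series into the measurable range. Only a lower bound on the size of this step can be read, and its full size stays open: the limit of > 100000 nM in this assay, at which 2 of the 4 values shown sit.

As far as these compounds go, whether the chlorine, the benzyl group or simply any large group on this nitrogen carries the change stays open; a plain benzyl, a methyl or a longer chain ending in an amine would separate these. From the compounds shown here alone, the role of the methyl group next to this nitrogen also stays open, as the step involving it cannot be read.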